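Ring Size on the Thiocarbonyl: Piperidine Against Pyrrolidine

This account rests on a few compounds, and the source may have more. Where it says the series, first, only, none or still open, it means among the compounds named here.

Three compounds have been measured in a functional assay on HeLa cells (Homo sapiens) for cytotoxicity, read by MTT assay, with a stated time of 72 h, tested at 100 uM; on this read-out lower numbers stand for less inhibition of growth and higher numbers for more inhibition of growth at the one concentration tested:

Compound 1, `Cc1cccc(/C(N)=N/NC(=S)N2CCCCC2)n1`, gives 85.4%.
Compound 2, `Cc1cccc(/C(N)=N/NC(=S)N2CCCC2)n1`, gives 80.1%.
Compound 3, `Cc1ccnc(/C(N)=N/NC(=S)N2CCCCC2)c1`, gives 70.8%.

Compound 1 and compound 2 share a core and differ only in the ring attached to the thiocarbonyl carbon: pyrrolidin-1-yl in place of piperidin-1-yl on a thiocarbonyl carbon. That exchange produced a number 5.3 percentage points lower from compound 1 to compound 2 (within the scatter), so on this read-out the two rings behave alike.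

Compound 3 carries the same thiocarbonyl and the same piperidin-1-yl ring as compound 1, but its core is built from the same atoms joined differently; the difference between the two cores is not broken down here. Compound 3 gives the lowest of the three numbers. Against compound 2 it lies within the scatter, while compound 1 stands higher than compound 3 by more than the scatter.

Compound 4, `Cc1ccnc(/C(N)=N/NC(=S)N2CCCC2)c1`, has not yet been measured. It relates to compound 3 exactly as compound 2 relates to compound 1: pyrrolidin-1-yl in place of piperidin-1-yl on a thiocarbonyl carbon. The place of the change is the same in both pairs, so this is the same change made on a different core. Because the step from compound 1 to compound 2 was a number 5.3 percentage points lower from compound 1 to compound 2 (within the scatter), the step from compound 3 to compound 4 is expected to be of similar small size, a number 5.8 percentage points lower from compound 3 to compound 4 (within the scatter), possibly a little lower than compound 3. The estimate for compound 4 in this assay is 65%, with a plausible range from 52% to 78%.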

Compound 4, percent growth inhibition at one concentration: 88.1%
Estimate against measurement, compound 4: 23.1 percentage points below, and the stated range ends below it.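

On the core of compound 3, pyrrolidin-1-yl in place of piperidin-1-yl on the thiocarbonyl carbon gave, in this assay, a number 17.3 percentage points higher from compound 3 to compound 4 (beyond the scatter). Within the data shown here, this result does not show why the same exchange behaves differently on the two cores, and with only one pair on each core, it cannot say what the exchange would do on a third core or whether either step would be repeated in a fresh measurement. It does show that, in this small series, the effect of the exchange did not carry over from one core to the other, so the step seen on one core was a poor guide to the step on the other, as the two steps set side by side make clear: the same change on two cores in this assay, a number 5.3 percentage points lower (within the scatter) from compound 1 to compound 2 and a number 17.3 percentage points higher (beyond the scatter) from compound 3 to compound 4, 22.6 percentage points apart, beyond the scatter of two such steps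

The compounds shown carry only the piperidin-1-yl and pyrrolidin-1-yl rings on the thiocarbonyl carbon, so it remains open whether a morpholin-4-yl ring, an azepan-1-yl ring or an open-chain dimethylamino group would also respond differently on the two cores. Every number here also comes from a single concentration in one cell line, which leaves open how these compounds would compare at lower concentrations or in other cells.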